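A few compounds are considered here, and "the series" means these few. Any claim that something is new, unique, unknown or untested is made for them only; others in the source may bear on it.

Of the compounds shown here, three have so far been measured in a functional assay, with a stated time of 150 min; on this read-out lower numbers stand for stronger inhibition and higher numbers for weaker inhibition. Compound 1 `CSc1nc(-c2ccc(N(C)C)cc2)c(C#N)c(=O)n1C` gives 93 ug/mL, compound 2 `CCOC(=O)c1cnn(-c2nc(-c3ccccc3O)c(C#N)c(=O)n2C)c1N` gives 64 ug/mL, and compound 3 `COc1cccc(-c2nc(NN)n(C)c(=O)c2C#N)c1OC` gives 54 ug/mL. Compound 2 stands second highest of the three numbers, its nearest neighbour being compound 3 and its furthest compound 1, yet both gaps lie within the scatter, so the three cannot be told apart. Compound 4 `CCOC(=O)c1cnn(-c2nc(-c3ccco3)c(C#N)c(=O)n2C)c1N` differs from compound 2 in one place: furan-2-yl in place of 2-hydroxyphenyl on an aromatic carbon. Among the compounds with values here, no measured pair shows this change. The step of a 1.1-fold higher number from compound 2 to compound 4 (0.04 log units; within the scatter) is expected to be small, in no firm direction, and likely within the scatter. Because compound 2 gives 64 ug/mL, compound 4 is estimated in this assay at 70 ug/mL, with a range from 30 ug/mL to 160 ug/mL.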

Compound 4, half-maximal inhibitory concentration: 108 ug/mL
For compound 4 the middle estimate is 1.5-fold (0.19 log units) below the measured one, and the stated range covers the measured number.
By their numbers in this assay, from the lowest: compounds 3, 2, 1 and 4 (each within the scatter of the next).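

Within the data shown here, the change from 2-hydroxyphenyl to furan-2-yl, on the aromatic carbon ortho to a cyano group, gives in this assay the only one-place comparison so far: a 1.7-fold higher number from compound 2 to compound 4 (0.23 log units; within the scatter). At this position, the two groups cannot be told apart, even though furan-2-yl has a smaller ring and carries no hydrogen-bond donor. Nothing available explains this result. The compounds shown leave open whether an amine or a carboxylic acid at this position would give a step beyond the scatter.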